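The source may hold more compounds than are shown below. What is called first, only, known or untested is meant among the compounds shown, and "the series" means these compounds.

Compound 1 `Cc1ccc(-c2nc3ccccc3s2)cc1NC(=O)c1cnccc1Cl` gives > 25000 nM in an ADME assay on HepG2 cells (Homo sapiens) for inhibition, with a stated time of 72 h (on this read-out higher numbers stand for an effect only at larger amounts of compound and lower numbers for an effect already at smaller amounts), a limit of the assay.
Compound 2 `COc1ccc(-c2nc3ccccc3s2)cc1NC(=O)c1cnccc1Cl` gives > 25000 nM in this assay, again only a limit.
Compound 3 `Cc1ccc(-c2nc3ccccc3o2)cc1NC(=O)c1cnccc1Cl` gives > 25000 nM in this assay, likewise a limit.

Compound 2 differs from compound 1 by methoxy in place of methyl on an aromatic carbon, and the resulting step that the two limits leave unreadable from compound 1 to compound 2 cannot be read, since (the limit of > 25000 nM in this assay, at which 3 of the 3 values shown sit). The core of compound 3 differs from that of compound 1, but that difference is not broken down here. Compound 4 `COc1ccc(-c2nc3ccccc3o2)cc1NC(=O)c1cnccc1Cl` has not yet been measured in this assay; it differs from compound 3 by methoxy in place of methyl on an aromatic carbon, the same change, at a place described in identical words. Because compound 3 sits at > 25000 nM and the earlier step is unreadable, the expected step is a step that the limit leaves unreadable from compound 3 to compound 4. Compound 4 is therefore estimated at 30000 nM, most likely reported again as a limit.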

Compound 4, half-maximal effective concentration: > 25000 nM
Compound 4: only a limit was reported (the forecaster's own chance of this, stated with the estimate: 85%); the middle value is on the limit's open side.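

No step can be read from compound 3 to compound 4 or from compound 2 to compound 4, since all of these values are limits: the limit of > 25000 nM in this assay, at which 4 of the 4 values shown sit.
In this assay the compounds shown leave open what size, if any, either change has.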